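Extending the Alkyl Ether Chain on a Benzamide Core

This account rests on a few compounds, and the source may have more. Where it says the series, first, only, none or still open, it means among the compounds named here.

Measured so far:
compound 1 `O=C1OCCN1C(=O)c1ccc(Oc2cccc(Cl)c2)cc1`: 7740 nM
compound 2 `CCCCOc1ccc(C(=O)N2CCOC2=O)cc1`: 1340 nM

Within the data shown here, in an assay on HEK293 cells for inhibition of N-acylethanolamine-hydrolyzing acid amidase (Rattus norvegicus), read by LC-MS, with a stated time of 30 min (a higher number here means a weaker inhibitor, a lower number a stronger inhibitor), compound 2 gives the lowest of the two numbers; the only other measured compound is compound 1, and the step of a 5.8-fold lower number from compound 1 to compound 2 (0.76 log units; beyond the scatter) runs beyond the scatter. Compound 3 `CCCCCCOc1ccc(C(=O)N2CCOC2=O)cc1` differs from compound 2 by ethyl in place of hydrogen on a saturated chain carbon, four bonds along the chain from an oxygen on an aromatic ring. Among the measured compounds shown here, no measured step alters the chain this way, so the swap from compound 1 to compound 2 bears on it only indirectly, suggesting this position tolerates change. A small gain is expected, with a 1.7-fold lower number from compound 2 to compound 3 (0.22 log units; within the scatter). Compound 3 is therefore estimated at 800 nM, ranging from 300 nM to 2500 nM.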

Compound 3, half-maximal inhibitory concentration: 640 nM
Compound 3: middle estimate off by 1.3-fold (0.10 log units), on the high side; the range from low to high includes it.
By their numbers in this assay, from the lowest: compound 3; then compound 2; then compound 1.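

Ethyl in place of hydrogen on a saturated chain carbon gives a 2.1-fold lower number from compound 2 to compound 3 (0.32 log units; beyond the scatter) as a real, if modest, gain, so this position does more than tolerate the added length. The hexyl ether gives a 12-fold lower number from compound 1 to compound 3 (1.08 log units; beyond the scatter) and widens the large gap between the alkyl and aryl ethers in these compounds. Nothing available explains why the number falls. From the compounds shown here alone, whether a longer chain would lower the number further, or the trend would stop, remains open. So does the effect of a chain carrying an amine or a carboxylic acid.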